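A few compounds are considered here, and "the series" means these few. Any claim that something is new, unique, unknown or untested is made for them only; others in the source may bear on it.

Measured in a functional assay on PC-3 cells (Homo sapiens) for inhibition, read by MTT assay, with a stated time of 48 h, tested at 10 uM; a lower number here means less inhibition of growth, a higher number more inhibition of growth at the concentration tested:
- Compound 1 `Cc1cc(=O)c2c(O)c(CN3CCCCC3)c(O)c([C@H]3CCN(C)C[C@H]3O)c2o1`: 14%
- Compound 2 `CN1CC[C@H](c2c(O)cc(O)c3c(=O)cc(/C=C/c4ccc(Cl)cc4)oc23)[C@H](O)C1`: 12%

Compound 2, at 12%, stands within the scatter of compound 1, at 14%, so the two measured compounds cannot be told apart in this assay. The next compound to be tested is compound 3 `CN1CC[C@H](c2c(O)cc(O)c3c(=O)cc(/C=C/c4c(F)c(F)c(F)c(F)c4F)oc23)[C@H](O)C1`, which keeps the shared core of compound 2 and carries a single change: 2,3,4,5,6-pentafluorophenyl in place of 4-chlorophenyl on a double-bonded chain carbon bound to a double-bonded chain carbon. Within the data shown here, no step between measured compounds that differ in one place is available, so the data do not show how far a single change can move this read-out. With only compound 2 at 12% as a direct reference, no step beyond the scatter is expected in either direction. The expected step is a number 3 percentage points higher from compound 2 to compound 3 (within the scatter). For compound 3 the estimated value is 15%, with an expected range from 3% to 32%.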

Compound 3, percent growth inhibition at one concentration: 82%
Compound 3: the middle estimate sits 67 percentage points below what was measured; measured number above the stated range.
By their numbers in this assay, from the lowest: compounds 2 and 1 (each within the scatter of the next); then compound 3.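

Among these compounds, putting 2,3,4,5,6-pentafluorophenyl in place of 4-chlorophenyl on a double-bonded chain carbon bound to a double-bonded chain carbon gives a number 70 percentage points higher from compound 2 to compound 3 (beyond the scatter) in this assay and shows that a single change at this place can move the read-out far beyond the scatter, which the earlier compounds could not show. Both groups hold one six-membered aromatic ring of carbon only, with no hydrogen-bond donors, no hydrogen-bond acceptors and no net charge, so the large step comes without any change in these counts. Nothing at hand explains why this exchange has so large an effect.

The compounds shown leave open whether the whole 2,3,4,5,6-pentafluorophenyl group is needed or whether 4-fluorophenyl or plain phenyl would give a similar number. Going by these compounds, whether the step carries over to other cells or other concentrations also stays open.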